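The compounds below may be only part of what the source reports. "The series", "measured", "known", "first", "only" and "open" are said of these compounds alone.

Compound 1 `O=C(O)c1cc(-c2cccc(COc3ccc4c(c3)CN(CC3CC3)C4=O)c2)ccc1Cl` gives 80 nM in an assay on HEK293 cells for positive allosteric modulation of metabotropic glutamate receptor 2 (Rattus norvegicus), read by thallium flux; a higher number here means that more compound is needed for the effect, a lower number that less compound is needed. Compound 2 `O=C(O)c1cc(-c2cccc(COc3ccc4c(c3)CN(Cc3ccc(C(F)(F)F)cc3)C4=O)c2)ccc1Cl` gives 350 nM. Compound 3 `Cc1c(OCc2cccc(-c3ccc(Cl)c(C(=O)O)c3)c2)cc2c(c1C)C(=O)C(C1CCCC1)C2` gives 180 nM.

Compound 2 has the highest number of the three; compound 3 sits within the scatter of it, while compound 1 is beyond it. Compound 4 `O=C(O)c1cc(-c2cccc(COc3ccc4c(c3)CN(C3CCCCC3)C4=O)c2)ccc1Cl` differs from compound 2 in one place: cyclohexyl in place of 4-(trifluoromethyl)benzyl on an amide-type nitrogen in a ring. Among the compounds with values here, one measured step bears on this change, a 4.4-fold higher number from compound 1 to compound 2 (0.64 log units; beyond the scatter), where an aromatic group took the place of a small saturated ring and the number rose. The move to compound 4 runs the other way, from an aromatic group back to a saturated ring, so a step of the size a 2.9-fold lower number from compound 2 to compound 4 (0.46 log units; beyond the scatter) is expected, toward a lower number. Compound 4 is therefore estimated at 120 nM, within a range of 40 nM to 400 nM.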

Compound 4, half-maximal effective concentration: 270 nM
Beside the measured number, compound 4's estimate is 2.3-fold (0.35 log units) below it; measured number inside the range.
By their numbers in this assay, from the lowest: compound 1; then compounds 3, 4 and 2 (each within the scatter of the next).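

In this assay replacing 4-(trifluoromethyl)benzyl with cyclohexyl on the amide-type nitrogen changes nothing measurable (a 1.3-fold lower number from compound 2 to compound 4 (0.11 log units; within the scatter)), so removing the aromatic ring does not by itself bring back the lower number of compound 1. Cyclohexyl in place of cyclopropylmethyl gives a 3.4-fold higher number from compound 1 to compound 4 (0.53 log units; beyond the scatter), so among these three groups on this nitrogen, only cyclopropylmethyl stands apart. Nothing available explains this. Still open, going by these compounds, is whether a plain methyl, a longer chain such as butyl, or a chain carrying an amine would match cyclopropylmethyl or give a lower number.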